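Chloro in Place of tert-Butyl on a Phenol Core

The compounds below may be only part of what the source reports. "The series", "measured", "known", "first", "only" and "open" are said of these compounds alone.

Compound 1, `COc1cc(C(=O)N2CCc3ccccc32)cc(C#N)c1O` — > 100000 nM
Compound 2, `CC(C)(C)c1cc(C(=O)N2CCc3ccccc32)cc(C#N)c1O` — 31600 nM

Of the compounds shown here, two have been measured in an assay on tissue (RPTEC cells) for inhibition of solute carrier family 22 member 12 (Homo sapiens), read by scintillation counting, with stated times of 15 min and 2 h; a higher number here means a weaker inhibitor, a lower number a stronger inhibitor. Compound 1 gives > 100000 nM in this assay, which is a limit of the assay rather than a number. Within the data shown here, compound 2 gives 31600 nM in this assay, the only actual number so far, so compound 2 stands as the one compound with a measured inhibitory concentration. The value of compound 1 is a limit (the limit of > 100000 nM in this assay, at which 1 of the 2 values shown sits). Among the measured compounds shown here, the single measured step, an at least 3.1-fold lower number from compound 1 to compound 2 (0.50 log units; beyond the scatter), shows that a tert-butyl group served better than a methoxy group on the same aromatic carbon.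

Compound 3, `N#Cc1cc(C(=O)N2CCc3ccccc32)cc(Cl)c1O`, has not been measured. It differs from compound 2 in one place: chloro in place of tert-butyl on an aromatic carbon. For the measured compounds named here, the only step available runs in the opposite direction, from a methoxy group toward the tert-butyl group, and it went beyond the scatter. Compound 3 again lacks the tert-butyl group on that carbon, so for compound 3 a weaker result is expected, with the step of a 2.2-fold higher number from compound 2 to compound 3 (0.35 log units; beyond the scatter). Compound 3 is therefore estimated at 70000 nM, within 15000 nM to 250000 nM.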

Compound 3, half-maximal inhibitory concentration: 14700 nM
For compound 3 the middle estimate is 4.8-fold (0.68 log units) above the measured one, outside the stated range (below it).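

In this assay, the tert-butyl group turns out not to be needed on this carbon, ortho to a hydroxy group: chloro, with 1 heavy atom against the 4 carbons of tert-butyl, gives a 2.1-fold lower number from compound 2 to compound 3 (0.33 log units; beyond the scatter). The earlier pair alone might have suggested that a larger group on this carbon gives a stronger inhibitor, but compound 3 goes against that reading, and among the three compounds it is now the strongest, so more heavy atoms do not by themselves give a lower number here. Chloro in place of methoxy gives an at least 6.8-fold lower number from compound 1 to compound 3 (0.83 log units; beyond the scatter), and this step has only a minimum size, since the value of compound 1 is a limit and not a number: the limit of > 100000 nM in this assay, at which 1 of the 3 values shown sits.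

These three compounds cannot tell what it is about chloro that gives the lower number, nor whether the same order would hold with other changes to the shared core. Only three groups are shown on this carbon, so it remains open how a bromo group, an amine, a carboxylic acid or a longer chain would fare there.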